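A few compounds are considered here, and "the series" means these few. Any claim that something is new, unique, unknown or untested is made for them only; others in the source may bear on it.

Of the compounds shown here, three have been measured in an ADME assay on THP-1 cells (Homo sapiens) for cytotoxicity, read by resazurin assay, with a stated time of 72 h; on this read-out higher numbers stand for lower toxicity in this test and lower numbers for higher toxicity in this test.
Compound 1, `CC(C)(C)c1ccc(C(=O)/C=C/c2ccco2)cc1`, gives > 50000 nM, a limit of this assay.
Compound 2, `O=C(/C=C/c1ccc([N+](=O)[O-])o1)c1ccc(-c2ccccc2)cc1`, gives 50400 nM.
Compound 3, `O=C(/C=C/c1ccc([N+](=O)[O-])o1)c1ccc(N2CCCCC2)cc1`, gives > 50000 nM, again a limit of this assay.

Compound 3 therefore stands at the upper limit of the assay, where two of the three values sit (the limit of > 50000 nM in this assay, at which 2 of the 3 values shown sit). Within the data shown here, the only step between measured compounds that differ in one place, a step that the limit leaves unreadable from compound 2 to compound 3, runs into this limit and its size cannot be read.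

Compound 4, `O=C(/C=C/c1ccco1)c1ccc(N2CCCCC2)cc1`, differs from compound 3 by hydrogen in place of nitro on an aromatic carbon. Among the measured compounds shown here, no measured step carries this exact change, but the two compounds already measured without the nitro group and with it are informative. Compound 1, which carries plain furan-2-yl, gives only the limit > 50000 nM. Compound 2, which carries 5-nitrofuran-2-yl, gives 50400 nM. On these numbers the removal of the nitro group is expected to move the read-out of compound 4 by no step beyond the scatter, a step that the limit leaves unreadable from compound 3 to compound 4, and the assay is expected to report a limit again. Compound 4 is thus estimated at 60000 nM, with a range from 30000 nM to 150000 nM.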

Compound 4, half-maximal cytotoxic concentration: > 50000 nM
Compound 4 was reported as a limit (the forecaster's own chance of this, stated with the estimate: 70%); the middle value lies beyond the limit too.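

In this assay compound 4 gives > 50000 nM, which is a limit of the assay. The steps from compound 3 and from compound 1 to compound 4 therefore cannot be read, and most values now sit at one limit: the limit of > 50000 nM in this assay, at which 3 of the 4 values shown sit.

The compounds shown leave open whether hydrogen in place of nitro changes this read-out at all.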